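The compounds below may be only part of what the source reports. "The series", "measured", "known", "first", "only" and "open" are said of these compounds alone.

Measured so far in a functional assay on SGC-7901 cells (Homo sapiens) for cytotoxicity, read by MTT assay, with a stated time of 48 h; a lower number here means a stronger inhibitor, a higher number a weaker inhibitor:
- compound 1 `O=C(CSc1ccc(Br)cc1)N1N=C(c2cc3ccccc3oc2=O)C[C@@H]1c1ccccc1C(F)(F)F` gives 14700 nM
- compound 2 `O=C(CSc1ccc(Br)cc1)N1N=C(c2cc3ccccc3oc2=O)C[C@@H]1c1ccccc1` gives 14300 nM
- compound 3 `O=C(CSc1ccc(Br)cc1)N1N=C(c2cc3ccccc3oc2=O)C[C@@H]1c1ccc(C(F)(F)F)cc1` gives 12100 nM

Compound 3 at 12100 nM cannot be separated from compound 1 or compound 2, so the three form one flat group. The next entry is compound 4 `CCCCSCC(=O)N1N=C(c2cc3ccccc3oc2=O)C[C@@H]1c1ccc(C(F)(F)F)cc1` where the change is butyl in place of 4-bromophenyl on a sulfur. The measured steps are a 1.0-fold lower number from compound 1 to compound 2 (0.01 log units; within the scatter) and a 1.2-fold lower number from compound 2 to compound 3 (0.07 log units; within the scatter) and also a 1.2-fold lower number from compound 1 to compound 3 (0.08 log units; within the scatter) and all three lie within the scatter. Among the compounds with values here, they concern only the trifluoromethyl group, while 4-bromophenyl stays on the sulfur throughout, so no measured step speaks directly to this change. In this assay a shift is therefore expected with low confidence, leaning towards a higher number. The estimated move is a 1.5-fold higher number from compound 3 to compound 4 (0.17 log units; within the scatter) and is expected to be modest. For compound 4 the expected value is 18000 nM with an estimated range from 7000 nM to 50000 nM given the absence of any direct precedent.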

Compound 4, half-maximal inhibitory concentration: 2910 nM
Compound 4: the middle estimate sits 6.2-fold (0.79 log units) above what was measured, and the stated range ends above it.
By their numbers in this assay, from the lowest: compound 4; then compounds 3, 2 and 1 (each within the scatter of the next).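

In this assay, within the data shown here, the group on the sulfur is the first place where a change moves the number beyond the scatter: butyl in place of 4-bromophenyl gives a 4.2-fold lower number from compound 3 to compound 4 (0.62 log units; beyond the scatter). The trifluoromethyl changes among compounds 1, 2 and 3 all stayed within the scatter, so this sulfur substituent is the only site shown so far to respond, and this single pair shows that an aromatic ring on the sulfur is not required for a number at this level. Nothing available accounts for the drop.

This one step removes the ring and the bromine together, so it cannot say which matters, or whether the chain itself contributes; a plain phenyl, a propyl or a hexyl on the sulfur would separate these readings. From the compounds shown here alone, whether butyl gives a similar step alongside the 2-(trifluoromethyl)phenyl or the unsubstituted phenyl of compounds 1 and 2 also remains open.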